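A methyl-to-phenyl swap, tried a second time

The source may report more compounds than this note shows. Statements on the series, on what has been measured and on what is new or still open speak of the compounds shown alone.

Of the compounds shown here, three have been measured in a functional assay on NCI-H2122 cells (Homo sapiens) for inhibition, read by microscopy, with a stated time of 10 days; a higher number here means a weaker inhibitor, a lower number a stronger inhibitor. Compound 1 `Cc1nn(C)c2c1C(c1cc(F)cc(F)c1)C(C#N)=C(N)O2` gives 4200 nM. Compound 2 `Cn1nc(-c2ccccc2)c2c1OC(N)=C(C#N)C2c1cc(F)cc(F)c1` gives 6600 nM in this assay. The two differ in one place: phenyl in place of methyl on an aromatic carbon. That change produced a 1.6-fold higher number from compound 1 to compound 2 (0.20 log units; within the scatter). Compound 3 `COc1ccc(C2C(C#N)=C(N)Oc3c2c(C)nn3C)cc1F` gives 5800 nM in this assay; its core differs from that of compound 1 in more than one place, and the difference between the two cores is not broken down here. Its value sits within the scatter of both compound 1 and compound 2, so no order among the three can be read from these numbers.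

Compound 4 `COc1ccc(C2C(C#N)=C(N)Oc3c2c(-c2ccccc2)nn3C)cc1F` has not yet been measured. It is obtained from compound 3 by the change already seen between compound 1 and compound 2: phenyl in place of methyl on an aromatic carbon. The place of the change is described in the same words in both pairs, so it is the same change on a different core. Because a 1.6-fold higher number from compound 1 to compound 2 (0.20 log units; within the scatter) stayed within the scatter, the step is expected to be small here as well: a 1.6-fold higher number from compound 3 to compound 4 (0.19 log units; within the scatter). On that basis compound 4 is estimated at 9000 nM in this assay, with a likely range from 4500 nM to 18000 nM.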

Compound 4, half-maximal inhibitory concentration: > 10000 nM
Compound 4: no number, only a limit (the forecaster's own chance of this, stated with the estimate: 10%); middle value at least 1.1-fold (0.04 log units) away from the limit.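

In this assay compound 4 gives > 10000 nM, which is a limit of the assay and not a number. Phenyl in place of methyl on this second core gives an at least 1.7-fold higher number from compound 3 to compound 4 (0.23 log units; that floor lies within the scatter), while the change of 3,5-difluorophenyl to 3-fluoro-4-methoxyphenyl on a saturated ring carbon gives an at least 1.5-fold higher number from compound 2 to compound 4 (0.18 log units; that floor lies within the scatter). The result shows no measurable sign that the phenyl change behaves differently on the two cores, but it does not show that the change carries over unaltered, and its true size on the second core stays unknown: the same change on two cores in this assay, a 1.6-fold higher number (0.20 log units; within the scatter) from compound 1 to compound 2 and an at least 1.7-fold higher number (0.23 log units; that floor lies within the scatter) from compound 3 to compound 4; the limit leaves it open whether they differ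

The compounds shown carry only methyl or phenyl on this aromatic carbon, so they leave open how an amine, a carboxylic acid or a longer chain at the same place would read in this assay. On these data alone, compounds 1, 2 and 3 lie within the scatter of one another, so it also remains open which group on the saturated ring carbon would give a step beyond the scatter.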